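The source may hold more compounds than are shown below. What is called first, only, known or untested is meant among the compounds shown, and "the series" means these compounds.

Compound 2 `CCOc1nc2cccc(C(=O)Nc3ccccc3)c2n1Cc1ccc(-c2ccccc2-c2nnn[nH]2)cc1` is the amide built on the shared core in which the amide nitrogen carries a phenyl group. In an assay on isolated protein for inhibition of NEDD8-activating enzyme E1 regulatory subunit (Homo sapiens), read by Western blot, with stated times of 10 min and 30 min, tested at 25 uM (a lower number here means less inhibition, a higher number more inhibition at the concentration tested (going by the name of the read-out)), compound 2 gives 34.6%. For the measured compounds named here, its only measured neighbour, compound 1 `CCOc1nc2cccc(C(=O)NCCCN(C)C)c2n1Cc1ccc(-c2ccccc2-c2nnn[nH]2)cc1`, gives 29.5%, and the step of a number 5.1 percentage points higher from compound 1 to compound 2 (within the scatter) shows the two standing together within the scatter. Compound 3 `CCOc1nc2cccc(C(=O)Nc3ccc(F)cc3)c2n1Cc1ccc(-c2ccccc2-c2nnn[nH]2)cc1` differs from compound 2 by fluoro in place of hydrogen on an aromatic carbon. Going by the values given here, no measured step touches this ring, and the one step known changed a different group without moving beyond the scatter. Compound 3 is therefore expected to show a number 0.6 percentage points lower from compound 2 to compound 3 (within the scatter), an estimate of 34%, ranging from 22% to 46%.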

Compound 3, a percentage reported as inhibition, at one concentration (the size of the read-out at that concentration, not a potency): 45.3%
Beside the measured number, compound 3's estimate is 11.3 percentage points below it, within the range that was stated.
By their numbers in this assay, from the lowest: compounds 1 and 2 (each within the scatter of the next); then compound 3.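

Adding a single fluoro to the phenyl ring on the amide nitrogen moves the result in this assay more than the earlier swap of the whole group on that nitrogen did: the step is a number 10.7 percentage points higher from compound 2 to compound 3 (beyond the scatter). Replacing 3-(dimethylamino)propyl with 4-fluorophenyl likewise gives a number 15.8 percentage points higher from compound 1 to compound 3 (beyond the scatter), so this ring position responds to change. Nothing available explains this rise. The compounds shown leave open whether chloro, methyl or methoxy in the same place would do the same, and whether fluoro elsewhere on the ring would.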